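A few compounds are considered here, and "the series" means these few. Any claim that something is new, unique, unknown or untested is made for them only; others in the source may bear on it.

Compound 1 `O=C(N/N=C/c1cc(I)cc(I)c1O)c1ccccc1`: in a functional assay on HepG2 cells (Homo sapiens) for cytotoxicity, with a stated time of 24 h (on this read-out lower numbers stand for stronger inhibition and higher numbers for weaker inhibition), compound 1 gives > 50000 nM, a limit of the assay.
Compound 2 `COc1ccc(C(=O)N/N=C/c2cc(I)cc(I)c2O)cc1`: in this assay compound 2 gives 45200 nM.
Compound 3 `Cc1ccc(C(=O)N/N=C/c2cc(I)c(O)c(I)c2)cc1`: in this assay compound 3 gives > 100000 nM, a limit of the assay.

Compound 3 therefore stands at the limit of > 100000 nM in this assay, at which 1 of the 3 values shown sits, and has no number of its own. Among the compounds with values here, the only measured step, an at least 1.1-fold lower number from compound 1 to compound 2 (0.04 log units; that floor lies within the scatter), is methoxy in place of hydrogen on an aromatic carbon, and it stays within the scatter. Compound 4 `CC(C)(C)c1ccc(C(=O)N/N=C/c2cc(I)c(O)c(I)c2)cc1` differs from compound 3 by tert-butyl in place of methyl on an aromatic carbon. Within the data shown here, no measured step follows an exchange of methyl for tert-butyl, so nothing among the measured compounds points to a step beyond the scatter in this assay in either direction. Compound 4 is expected to give 120000 nM, between 30000 nM and 500000 nM. The expected step is a step that the limit leaves unreadable from compound 3 to compound 4.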

Compound 4, half-maximal inhibitory concentration: 45900 nM
Beside the measured number, compound 4's estimate is 2.6-fold (0.42 log units) above it; the measured number falls inside the stated range.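

In this assay, within the data shown here, tert-butyl in place of methyl on an aromatic carbon, para to a large group, gives an at least 2.1-fold lower number from compound 3 to compound 4 (0.33 log units; beyond the scatter), so an exchange at this position can move the number, whereas the only earlier step stayed within the scatter. Compound 3 has only a limit of the assay and no number of its own, so the true size of the step stays unknown: the limit of > 100000 nM in this assay, at which 1 of the 4 values shown sits.

As far as these compounds go, whether an amine or a carboxylic acid at this position would shift the number in the same direction remains open. So does whether tert-butyl would have the same effect on the core of compound 1.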